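This account rests on a few compounds, and the source may have more. Where it says the series, first, only, none or still open, it means among the compounds named here.

Series notes. Compound 1 `CCCC1CCC(OC(=O)N[C@@H](CC(C)C)C(=O)N[C@H](C=O)C[C@@H]2CCNC2=O)CC1` and compound 2 `CCCC1CCC(OC(=O)N[C@@H](CC(C)C)C(=O)N[C@@H](C[C@@H]2CCNC2=O)C(O)S(=O)(=O)O)CC1` share one core and differ in a single place. In a toxicity assay on Huh-7 cells (Homo sapiens) for cytotoxicity (a higher number here means that more compound is tolerated, a lower number that less compound is tolerated), compound 1 gives only a limit, > 100000 nM. In this assay compound 2 also gives only a limit, > 100000 nM. The step that the two limits leave unreadable from compound 1 to compound 2 is therefore not readable, since both values sit at the limit of > 100000 nM in this assay, at which 2 of the 2 values shown sit. Among the measured compounds shown here, compound 2 thus stands at the limit, and the one further value shown, that of compound 1, is a limit as well. Compound 3 `CC(C)C[C@H](NC(=O)OC1CCCCC1)C(=O)N[C@@H](C[C@@H]1CCNC1=O)C(O)S(=O)(=O)O` differs from compound 2 by hydrogen in place of propyl on a saturated ring carbon. For the measured compounds named here, no measured step bears on this change; the only known step, a step that the two limits leave unreadable from compound 1 to compound 2, concerns another part of the structure and has no readable size. Compound 3 is therefore expected to remain at the limit, with a step that the limit leaves unreadable from compound 2 to compound 3 expected to be no step beyond the scatter. The estimate for compound 3 in this assay is 150000 nM, ranging from 60000 nM to 400000 nM.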

Compound 3, half-maximal cytotoxic concentration: > 100000 nM
Compound 3: a limit, no number (the forecaster's own chance of this, stated with the estimate: 85%); the middle value is on the limit's open side.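

In this assay compound 3 gives > 100000 nM as a limit only. Among the compounds shown here, no step from compound 2 to compound 3 can be read, since every value shown sits at one limit: the limit of > 100000 nM in this assay, at which 3 of the 3 values shown sit. The compounds shown leave open at what concentration any of them becomes cytotoxic, and whether 4-propylcyclohexyl to cyclohexyl changes that concentration.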